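Thiazolyl amide to cyanamide on an angiotensin receptor series

The source may report more compounds than this note shows. Statements on the series, on what has been measured and on what is new or still open speak of the compounds shown alone.

Measured so far:
compound 1, `CC[C@H](C)[C@H](NC(=O)c1cccc(Cn2ccnc2)c1)C(=O)NNS(=O)(=O)c1c(C)cc(C)cc1C`, 27%
compound 2, `CC[C@H](C)[C@H](NC(=O)c1cccc(Cn2ccnc2)c1)C(=O)Nc1nccs1`, 17%

Both compounds were tested in an assay on HEK293 cells for displacement of a labelled ligand from Type-2 angiotensin II receptor (Homo sapiens), tested at 10 uM; a lower number here means a weaker effect, a higher number a stronger effect of the compound at the concentration tested. Compound 1 gives 27% in this assay, and compound 2 gives 17%. Going by the values given here, of the two numbers, the one for compound 2 stands nearer the bottom of the scale, yet its distance from compound 1 falls within the usual scatter of this kind of measurement, so the two compounds cannot be told apart on these data.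

The next compound, compound 3, is `CC[C@H](C)[C@H](NC(=O)c1cccc(Cn2ccnc2)c1)C(=O)NC#N`. It differs from compound 2 in one place: cyano in place of 1,3-thiazol-2-yl on an amide-type nitrogen. Among the compounds with values here, the rest of the shared core is untouched, and no step between two measured compounds speaks to this change.

Within the data shown here, with only two weak numbers in hand and no comparable step, compound 3 is expected to stay in the same weak region. The step of a number 4 percentage points lower from compound 2 to compound 3 (within the scatter) is expected to be small, not clearly beyond the scatter, with a slight lean downward if anything. For compound 3 the estimate in this assay is 13%, within a range from 0% to 30%.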

Compound 3, a percentage reported as inhibition, at one concentration (the size of the read-out at that concentration, not a potency): 9%
Compound 3: middle estimate off by 4 percentage points, on the high side; the range from low to high includes it.
By their numbers in this assay, from the lowest: compounds 3, 2 and 1 (each within the scatter of the next, the first and the last beyond it).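

In this assay, going by these compounds alone, cyano in place of 1,3-thiazol-2-yl on the amide-type nitrogen gives a number 8 percentage points lower from compound 2 to compound 3 (within the scatter), the first direct reading of a single change at this position. The five-membered aromatic ring, with 5 heavy atoms, can thus be exchanged for a group of 2 heavy atoms with no ring, and the two compounds still cannot be told apart, so these data do not show that the ring is needed for the small read-out of compound 2. No measurement shown here offers an explanation for this result.

A step within the scatter between two low read-outs leaves open whether the group on this nitrogen matters at all in this assay, or whether the series simply sits too low for a change here to register. As far as these compounds go, it also remains open whether a carboxylic acid, a primary amine or a longer alkyl chain on the same amide-type nitrogen, with the rest of the shared core untouched, would give a read-out clearly apart from that of compound 2.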